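The source may report more compounds than this note shows. Statements on the series, on what has been measured and on what is new or still open speak of the compounds shown alone.

- Compound 1 `Cc1c(C)c2c(c(C)c1N)CC(C)(C)O2`: 760 nM
- Compound 2 `Cc1c(C)c2c(c(C)c1N)CC(C)(CSc1ccc(O)cc1)O2`: 220 nM
- Compound 3 `CCCSCC1(C)Cc2c(C)c(N)c(C)c(C)c2O1`: 280 nM

In a functional assay (microsomes, liver) with Rattus norvegicus as the target (on this read-out lower numbers stand for stronger inhibition and higher numbers for weaker inhibition), compound 3 has a clearly lower number than compound 1 and sits within the scatter of compound 2. Compound 4 `COCC1(C)Cc2c(C)c(N)c(C)c(C)c2O1` keeps the shared core but carries methoxy in place of propylsulfanyl on a saturated chain carbon bound to a saturated ring carbon.

Within the data shown here, no measured step makes this exact swap, but two bear on it. Changing the group on the sulfur gave a 1.3-fold higher number from compound 2 to compound 3 (0.10 log units; within the scatter), which says little here, since the sulfur stayed in place. Putting propylsulfanyl in place of hydrogen gave a 2.7-fold lower number from compound 1 to compound 3 (0.43 log units; beyond the scatter), a modest step. Methoxy is a different and shorter group, so part of that step may be lost, and the number in this assay should go up rather than down. The expected step is a 1.6-fold higher number from compound 3 to compound 4 (0.21 log units; within the scatter). For compound 4 the estimated value is 450 nM, with an expected range of 220 nM to 900 nM.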

Compound 4, half-maximal inhibitory concentration: 300 nM
Beside the measured number, compound 4's estimate is 1.5-fold (0.18 log units) above it; measured number inside the range.
By their numbers in this assay, from the lowest: compounds 2, 3 and 4 (each within the scatter of the next); then compound 1.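

In this assay, methoxy in place of propylsulfanyl on this saturated chain carbon gives no real change (a 1.1-fold higher number from compound 3 to compound 4 (0.03 log units; within the scatter)), so neither the sulfur nor the propyl chain is needed to keep the number where it is. Methoxy in place of hydrogen still gives a modest gain (a 2.5-fold lower number from compound 1 to compound 4 (0.40 log units; beyond the scatter)), which shows that the lower number of compounds 2, 3 and 4 against compound 1 does not depend on sulfur being present. No measurement shown here explains why these different groups give such similar numbers.

Going by these compounds, it remains open whether an amine or a carboxylic acid on this carbon would keep the number in the same range. On these data alone, a longer chain on the oxygen of the methoxy group is an equally open case.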